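Trimming a methoxy group from the aryl ketone

The source may report more compounds than this note shows. Statements on the series, on what has been measured and on what is new or still open speak of the compounds shown alone.

Compound 2 `COc1ccc(C(=O)/C=C/c2cc(-c3cc(OC)c(OC)c(OC)c3)n[nH]2)cc1OC` holds the lower of the two numbers in a functional assay on PC-3 cells (Homo sapiens) for inhibition, read by sulforhodamine B assay, with a stated time of 48 h (a lower number here means a stronger inhibitor of growth, a higher number a weaker inhibitor of growth), where compound 2 gives 1360 nM. Compound 1 `COc1cc(-c2cc(/C=C/C(=O)c3ccc(Cl)c(Cl)c3)[nH]n2)cc(OC)c1OC` gives 5950 nM in this assay, and the step of a 4.4-fold lower number from compound 1 to compound 2 (0.64 log units; beyond the scatter) is the only measured one. Compound 3 `COc1ccc(C(=O)/C=C/c2cc(-c3cc(OC)c(OC)c(OC)c3)n[nH]2)cc1` differs from compound 2 by hydrogen in place of methoxy on an aromatic carbon, a change that step does not cover, since it exchanged whole aryl groups on the carbonyl carbon. Among the measured compounds shown here, with no direct precedent, a step no larger than the scatter is expected, a 1.5-fold higher number from compound 2 to compound 3 (0.17 log units; within the scatter). Compound 3 is estimated at 2000 nM, within 700 nM to 6000 nM.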

Compound 3, concentration for 50% growth inhibition: 1510 nM
The estimate for compound 3 lay 1.3-fold (0.12 log units) above the measured number; the range from low to high includes it.
By their numbers in this assay, from the lowest: compounds 2 and 3 (each within the scatter of the next); then compound 1.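

Replacing the methoxy with hydrogen on this aromatic carbon (a 1.1-fold higher number from compound 2 to compound 3 (0.05 log units; within the scatter)) leaves the two compounds indistinguishable in this assay, so the change from 3,4-dimethoxyphenyl to 4-methoxyphenyl has no readable effect here. The separation from the 3,4-dichlorophenyl ketone persists with the single methoxy (a 3.9-fold lower number from compound 1 to compound 3 (0.60 log units; beyond the scatter)), so in this pair that separation does not depend on the methoxy removed. No evidence is available that bears on this result.

Still open, on these data alone, is whether a hydroxyl group, an ethoxy group or an amine on this aromatic carbon would shift the number. As far as these compounds go, the outcome of replacing the remaining methoxy of the 4-methoxyphenyl group with hydrogen is also open.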